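Shifting a methoxy substituent: from compound 2 to compound 3

The source may hold more compounds than are shown below. What is called first, only, known or untested is meant among the compounds shown, and "the series" means these compounds.

Compound 1 `C#Cc1cccc(Nc2ncnc3cc(OC)c(OCCCCC(=O)Nc4ccc(S(N)(=O)=O)cc4)cc23)c1` gives 18800 nM in a functional assay on NCI-H1975 cells (Homo sapiens) for antiproliferative activity, read by MTT assay, with a stated time of 72 h; a lower number here means a stronger inhibitor, a higher number a weaker inhibitor.
Compound 2 `COc1ccc(Nc2ncnc3cc(OC)c(OCCCCC(=O)Nc4ccc(S(N)(=O)=O)cc4)cc23)cc1` gives 30200 nM in this assay.

Of the two numbers measured, compound 2 holds the higher one, yet the step of a 1.6-fold higher number from compound 1 to compound 2 (0.21 log units; within the scatter) lies within the scatter, so the two compounds cannot be ordered on this evidence. Compound 3 `COc1ccccc1Nc1ncnc2cc(OC)c(OCCCCC(=O)Nc3ccc(S(N)(=O)=O)cc3)cc12` is built from compound 2 by 2-methoxyphenyl in place of 4-methoxyphenyl on a nitrogen on an aromatic ring. Among the measured compounds shown here, only one measured step touches the group on this nitrogen, the one from compound 1 to compound 2, and that step was within the scatter. It concerns a different pair of groups and says nothing directly about shifting the methoxy from one place on the ring to another. For the measured compounds named here, no measured step moves this substituent. The account can therefore only expect that compound 3 stays in the same weak range as compound 2, with a step of a 1.2-fold higher number from compound 2 to compound 3 (0.06 log units; within the scatter) that is expected to lie within the scatter. Compound 3 is thus estimated at 35000 nM in this assay, with an expected range from 12000 nM to 100000 nM. Going by the values given here, the width of that range reflects how little the single measured step constrains this change.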

Compound 3, half-maximal inhibitory concentration: 8030 nM
For compound 3 the middle estimate is 4.4-fold (0.64 log units) above the measured one, and the stated range ends above it.
By their numbers in this assay, from the lowest: compound 3; then compounds 1 and 2 (each within the scatter of the next).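

In this assay the position of the methoxy on the ring carried by the nitrogen proves to matter: the change to 2-methoxyphenyl gives a 3.8-fold lower number from compound 2 to compound 3 (0.58 log units; beyond the scatter) even though the group that leaves and the group that enters have the same atoms and the same counts. The earlier step between compound 1 and compound 2 could not separate the groups on this nitrogen, whereas 2-methoxyphenyl also stands apart from 3-ethynylphenyl, with a 2.3-fold lower number from compound 1 to compound 3 (0.37 log units; beyond the scatter) and so makes compound 3 the most potent of the three shown, though both steps are modest. No measurement available here accounts for this difference between the two methoxy placements.

Whether the shift in the number belongs to the methoxy itself or would follow other groups at that place stays open, as 2-methoxyphenyl is the only such ring among these compounds, and a hydroxyl, an amine or a fluorine there might read differently. Going by these compounds, the chain and the sulfonamide are the same in all three compounds, so it also remains open how a longer chain or a carboxylic acid in place of the sulfonamide would behave alongside 2-methoxyphenyl.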